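This account rests on a few compounds, and the source may have more. Where it says the series, first, only, none or still open, it means among the compounds named here.

Measured so far in a functional assay on the whole organism (strain Albino Swiss CD1) with Mus musculus as the target, in the maximal electroshock model; on this read-out higher numbers stand for an effect only at larger amounts of compound and lower numbers for an effect already at smaller amounts:
compound 1, `CCC(C(=O)NCc1ccccc1Cl)N1C(=O)CCC1=O`: 113 mg/kg
compound 2, `CCC(C(=O)NCc1cccc(Cl)c1)N1C(=O)CCC1=O`: 96.6 mg/kg
compound 3, `CC1CC(=O)N(C(C)C(=O)NCc2ccccc2Cl)C1=O`: 85.9 mg/kg

Compound 4, `CC1CC(=O)N(C(C)C(=O)NCc2cccc(Cl)c2)C1=O`, has not yet been measured in this assay.

Compounds 1 and 2 share one core; compound 3 carries a different core, and the difference between the two cores is not broken down here. The change from compound 1 to compound 2 is 3-chlorophenyl in place of 2-chlorophenyl on a saturated chain carbon bound to an amide-type nitrogen. That step gave a 1.2-fold lower number from compound 1 to compound 2 (0.07 log units; within the scatter). The change from compound 3 to compound 4 is 3-chlorophenyl in place of 2-chlorophenyl on a saturated chain carbon bound to an amide-type nitrogen, the same change at the same place, so the pair is the second occurrence of this change in the series.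

All three measured values lie within the scatter of one another, so no ordering among compounds 1, 2 and 3 can be drawn from them.

Going by the values given here, for compound 4 a step of about a 1.1-fold lower number from compound 3 to compound 4 (0.06 log units; within the scatter) is expected, a move of the same small size as the one from compound 1 to compound 2, because that step measured a 1.2-fold lower number from compound 1 to compound 2 (0.07 log units; within the scatter). On this basis compound 4 is estimated at 75 mg/kg in this assay, expected to fall between 45 mg/kg and 130 mg/kg.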

Compound 4, dose for half-maximal effect: 90.3 mg/kg
Compound 4: the middle estimate sits 1.2-fold (0.08 log units) below what was measured, within the range that was stated.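

In this assay, 3-chlorophenyl in place of 2-chlorophenyl gave a 1.1-fold higher number from compound 3 to compound 4 (0.02 log units; within the scatter), and the two occurrences of this change do not differ: the same change on two cores in this assay, a 1.2-fold lower number (0.07 log units; within the scatter) from compound 1 to compound 2 and a 1.1-fold higher number (0.02 log units; within the scatter) from compound 3 to compound 4, 1.2-fold (0.09 log units) apart, within the scatter of two such steps

On the cores shown, the change therefore carries from one core to the other in the limited sense that both steps stay within the scatter. Going by these compounds alone, this does not show that a step of real size would carry between these cores, and with only two pairs, neither beyond the scatter, no direction of effect or general rule for the series can be drawn.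

Every compound shown carries a chlorophenyl group, so it remains open whether unsubstituted phenyl, methoxyphenyl or trifluoromethylphenyl on the same chain would produce a step beyond the scatter. From the compounds shown here alone, it also remains open whether such a step, or one from an amine or a longer chain on the saturated chain carbon, would keep its size from one core to the other.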